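The source may hold more compounds than are shown below. What is called first, only, known or untested is meant among the compounds shown, and "the series" means these compounds.

Compound 2 `O=[N+]([O-])c1c(CS(=O)(=O)c2ccccc2)nc2c(-c3ccc(O)cc3)cc(Cl)cn12` carries a 4-hydroxyphenyl group on the shared core, and in an ADME assay on HepG2 cells (Homo sapiens) for cytotoxicity, read by MTT assay, with a stated time of 72 h (on this read-out higher numbers stand for lower toxicity in this test and lower numbers for higher toxicity in this test), compound 2 reaches only a limit of > 12500 nM. Compound 1 `CCN(CC)c1ccc(-c2cc(Cl)cn3c([N+](=O)[O-])c(CS(=O)(=O)c4ccccc4)nc23)cc1` likewise stops at a limit, giving > 15600 nM in this assay. Compound 3 `O=[N+]([O-])c1c(CS(=O)(=O)c2ccccc2)nc2c(-c3cccnc3)cc(Cl)cn12` also gives only a limit, > 31300 nM. Because all three values sit at the limit of > 12500 nM in this assay, at which 1 of the 3 values shown sits, the limit of > 15600 nM in this assay, at which 1 of the 3 values shown sits, and (the limit of > 31300 nM in this assay, at which 1 of the 3 values shown sits), the steps a step that the two limits leave unreadable from compound 1 to compound 2 and a step that the two limits leave unreadable from compound 2 to compound 3 cannot be read, and compound 2 stands among three values that are limits alone. Compound 4 `O=[N+]([O-])c1c(CS(=O)(=O)c2ccccc2)nc2c(-c3ccco3)cc(Cl)cn12` differs from compound 2 by furan-2-yl in place of 4-hydroxyphenyl on an aromatic carbon. With no readable step to lean on, compound 4 is expected to remain a limit as well, so the step that the limit leaves unreadable from compound 2 to compound 4 is expected to stay within the scatter. Compound 4 is estimated at 20000 nM, between 10000 nM and 60000 nM.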

Compound 4, half-maximal cytotoxic concentration: > 3900 nM
Compound 4 ended at the assay's limit (the forecaster's own chance of this, stated with the estimate: 85%); the middle value lies beyond the limit too.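

Compound 4 also gives only a limit, and its steps to compound 1, compound 2 and compound 3 cannot be read. The compounds shown leave open whether these four groups on the shared core differ at all in this assay.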